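The source may hold more compounds than are shown below. What is called first, only, known or untested is meant among the compounds shown, and "the series" means these compounds.

In a functional assay on MCF7 cells (Homo sapiens) for antiproliferative activity, read by CellTiter-Glo, with a stated time of 5 days (on this read-out lower numbers stand for stronger inhibition and higher numbers for weaker inhibition), compound 1 `CC1=C(c2ccc(C#N)cc2)C(c2ccc(OC[C@H](C)N3CC[C@@H](C)C3)cc2)Oc2ccc(O)cc21` gives 10 nM. Compound 2 `CC1=C(c2cccc(O)c2)C(c2ccc(OC[C@@H](C)N3CC[C@H](C)C3)cc2)Oc2ccc(O)cc21` gives 0.2 nM, which leaves compound 1 with the higher of the two numbers, and the gap between them lies beyond the usual scatter. For the measured compounds named here, no two measured compounds differ in one place only, so the data offer no direct precedent for a single change.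

Compound 3 `CC1=C(c2cccc(C#N)c2)C(c2ccc(OC[C@H](C)N3CC[C@@H](C)C3)cc2)Oc2ccc(O)cc21` has not yet been measured. It has the same atoms as compound 1, joined differently: 3-cyanophenyl stands in place of 4-cyanophenyl on a double-bonded ring carbon, next to the ring atom that bears a large group (3-cyanophenyl in place of 4-cyanophenyl on a double-bonded ring carbon).

A modest step toward a lower number is expected in this assay, possibly not far beyond the scatter. That expectation rests only weakly on compound 2, at 0.2 nM, which shows that lower numbers are reachable among these compounds. The estimate amounts to an expected 2.5-fold lower number from compound 1 to compound 3 (0.40 log units; beyond the scatter). For compound 3 the estimated value is 4 nM, within an expected range of 0.7 nM to 20 nM.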

Compound 3, half-maximal inhibitory concentration: 2.6 nM
Compound 3: middle estimate off by 1.5-fold (0.19 log units), on the high side; measured number inside the range.
By their numbers in this assay, from the lowest: compound 2; then compound 3; then compound 1.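

In this assay, for the compounds shown here, the step from 4-cyanophenyl to 3-cyanophenyl on the double-bonded ring carbon gives a 3.8-fold lower number from compound 1 to compound 3 (0.59 log units; beyond the scatter) and is the first comparison here that isolates a single change. Because compound 1 and compound 3 have the same atoms, joined differently, it shows that the position of the nitrile on this phenyl ring alone can move the number beyond the usual scatter, something compound 1 and compound 2 could not show, since they differ in more than one place. Nothing in the data accounts for the size or direction of this step.

Compound 2 also differs from compound 3 in more than one place, so how much of its lower number belongs to the group at this position remains unresolved. On these data alone, it is also open whether a change of position would act the same way for other groups on this ring, such as a trifluoromethyl group, a carboxylic acid or an amide, and how any of these would compare with a plain phenyl ring at the same place.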